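A few compounds are considered here, and "the series" means these few. Any claim that something is new, unique, unknown or untested is made for them only; others in the source may bear on it.

Working notes on the series. The shared core carries a tert-butyl-substituted benzoyl group in compound 1 `CC(C)(C)OC(=O)NCCCCNC(=O)CN1CN(c2ccccc2)C2(CCN(C(=O)c3ccc(C(C)(C)C)cc3)CC2)C1=O` and a cyclohexyl-substituted benzoyl group in compound 2 `CC(C)(C)OC(=O)NCCCNC(=O)CN1CN(c2ccccc2)C2(CCN(C(=O)c3ccc(C4CCCCC4)cc3)CC2)C1=O` and compound 3 `CC(C)(C)OC(=O)NCC1CCCN(C(=O)CN2CN(c3ccccc3)C3(CCN(C(=O)c4ccc(C5CCCCC5)cc4)CC3)C2=O)C1`. In an assay on HEK293 cells for displacement of a labelled ligand from NPC1-like intracellular cholesterol transporter 1 (Homo sapiens) (a higher number here means a weaker inhibitor, a lower number a stronger inhibitor), compound 1 gives "not determined" (no result reported), so compound 1 stands without a number of its own. In this assay compound 2 gives 6000 nM. In this assay compound 3 gives 3800 nM. These two values lie within the scatter of each other and show the series as weak throughout on the numbers available.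

Compound 4 `CC(C)(C)c1ccc(C(=O)N2CCC3(CC2)C(=O)N(CC(=O)NCN)CN3c2ccccc2)cc1` is reached from compound 1 by the change (amino in place of 3-((tert-butoxycarbonyl)amino)propyl on a saturated chain carbon bound to an amide-type nitrogen). Going by the values given here, no step between measured compounds separates this change out, and compound 1 itself has no value, so the size of the step in this assay cannot be read from a pair; on the weak numbers of compound 2 and compound 3, no movement beyond the scatter is expected, with a weaker result somewhat more likely than a stronger one. For compound 4 the value in this assay is estimated at 8000 nM, expected between 2000 nM and 30000 nM.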

Compound 4, half-maximal inhibitory concentration: 26500 nM
Beside the measured number, compound 4's estimate is 3.3-fold (0.52 log units) below it, and the stated range covers the measured number.
By their numbers in this assay, from the lowest: compounds 3 and 2 (each within the scatter of the next); then compound 4.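

Going by these compounds alone, no step to compound 4 can be read: compound 1 gives "not determined" (no result reported) in this assay and so offers no number to start from. Going by these compounds, the effect of amino in place of 3-((tert-butoxycarbonyl)amino)propyl alone stays open, and no supporting data bear on the result of compound 4.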